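This account rests on a few compounds, and the source may have more. Where it says the series, first, only, none or still open, it means among the compounds named here.

Measured so far, each value a limit of the assay:

compound 1 `CC(C(=O)O)c1nn(Cc2cn3cc(OCC4CC4)c(Cl)cc3n2)c2ccccc2c1=O`: < 8.34 mL/min/kg
compound 2 `O=C(O)Cn1nc(Cn2cc3cc(OCC4CC4)c(Cl)cc3n2)c2ccccc2c1=O`: < 11.7 mL/min/kg

The read-out in an ADME assay on cells (Hepatocyte, Homo sapiens) for metabolic stability, read by LC-MS, with a stated time of 180 min, tested at 1 uM (a lower number here means slower removal, a higher number faster removal of the compound), is clearance. Compound 1 stands at < 8.34 mL/min/kg, which is a limit and not a number. Its place relative to compound 2 therefore cannot be ordered.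

Compound 3 `O=C(O)Cc1nn(Cc2cn3cc(OCC4CC4)c(Cl)cc3n2)c2ccccc2c1=O` is the next to be read. It differs from compound 1 by hydrogen in place of methyl on a saturated chain carbon bound to an aromatic carbon and a carbonyl carbon, with hydrogen in place of methyl on a saturated chain carbon bound to an aromatic carbon and a carbonyl carbon. The 1-carboxyethyl thus becomes carboxymethyl.

Among the measured compounds shown here, no measured step covers this change, so no step beyond the scatter is expected in this assay, and no direction is favoured. The estimated step of an at least 1.0-fold higher number from compound 1 to compound 3 (0.03 log units; that floor lies within the scatter) is expected to stay within that scatter. For compound 3 the estimated clearance is 9 mL/min/kg, with an expected range of 4 mL/min/kg to 20 mL/min/kg.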

Compound 3, clearance: < 6.67 mL/min/kg
Compound 3: only a limit was reported; the forecaster's own chance of this, stated with the estimate: 75%; middle value at least 1.3-fold (0.13 log units) away from the limit.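

No step can be read from compound 1 to compound 3 in this assay, as both results are limits and not numbers. The compounds shown leave open whether the change from 1-carboxyethyl to carboxymethyl alters clearance at all, and the true clearance of each compound.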